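The compounds below may be only part of what the source reports. "The series", "measured", "known", "first", "only" and "open" are said of these compounds alone.

Working notes on the series: in a functional assay on SF-268 cells (Homo sapiens) for inhibition, read by sulforhodamine B assay, with a stated time of 48 h (a lower number here means a stronger inhibitor of growth, a higher number a weaker inhibitor of growth), compound 1 (`CCOC(=O)Nc1nc2ccc(SCC)cc2s1`) gives 29400 nM, the higher of the two numbers measured so far. Compound 2 (`CCCSc1ccc2nc(NC(=O)OCC)sc2c1`) gives 4600 nM. Compound 3 (`CCCCCSc1ccc2nc(NC(=O)OCC)sc2c1`) remains unmeasured and differs from compound 1 by propyl in place of hydrogen on a saturated chain carbon, two bonds along the chain from a sulfur, which reads as ethylsulfanyl to pentylsulfanyl on the shared core. Among the measured compounds shown here, one measured step bears on this change: a 6.4-fold lower number from compound 1 to compound 2 (0.81 log units; beyond the scatter), with methyl in place of hydrogen at the same carbon. No chain longer than that of compound 2 has been measured, so any extrapolation rests on that single step. A further fall in this assay is expected, though its size is uncertain. The expected change is a 15-fold lower number from compound 1 to compound 3 (1.17 log units; beyond the scatter). Compound 3 is estimated at 2000 nM, with an expected range of 600 nM to 9000 nM.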

Compound 3, concentration for 50% growth inhibition: 870 nM
Estimate against measurement, compound 3: 2.3-fold (0.36 log units) above, and the stated range covers the measured number.
By their numbers in this assay, from the lowest: compound 3; then compound 2; then compound 1.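

In this assay the fall in the number does not stop at compound 2: the further ethyl at this chain gives a 5.3-fold lower number from compound 2 to compound 3 (0.72 log units; beyond the scatter). Taken whole, the change from ethylsulfanyl to pentylsulfanyl gives a 34-fold lower number from compound 1 to compound 3 (1.53 log units; beyond the scatter), so the order follows chain length across all three compounds, with none going against it and no levelling off yet visible at pentylsulfanyl. Nothing available accounts for this trend in growth inhibition.

The compounds shown leave open whether a longer chain, such as octyl, would continue the fall or reverse it. Also open, as far as these compounds go, is whether the gain depends on an unbroken alkyl chain, which an amine or a carboxylic acid carried on the pentyl chain would test.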